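The source may report more compounds than this note shows. Statements on the series, on what has been measured and on what is new or still open speak of the compounds shown alone.

Compound 1 `COc1ccc(-c2nc3cc(NC(=O)[C@H](C)Oc4cccc(F)c4F)ccc3o2)cc1` is the reference point of this small set. In an assay on isolated protein for inhibition of GMP reductase 2 (Homo sapiens), read by spectrophotometry (a higher number here means a weaker inhibitor, a lower number a stronger inhibitor), compound 1 gives only a limit, > 5000 nM. Compound 2 `COc1ccc(-c2nc3cc(NC(=O)[C@H](C)Oc4ccccc4CN)ccc3o2)cc1` likewise stops at a limit in this assay, > 5000 nM. Compound 3 `COc1ccc(-c2nc3cc(NC(=O)[C@H](C)Oc4cccc(Cl)c4Cl)ccc3o2)cc1` also reaches no more than a limit in this assay, > 5000 nM. The three values sit together at the limit of > 5000 nM in this assay, at which 3 of the 3 values shown sit, so none of the steps among them has a readable size: a step that the two limits leave unreadable from compound 1 to compound 2, a step that the two limits leave unreadable from compound 1 to compound 3 and a step that the two limits leave unreadable from compound 2 to compound 3 all remain unreadable.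

Compound 4 `C[C@H](Oc1cccc(F)c1F)C(=O)Nc1ccc2oc(-c3ccc(O)cc3)nc2c1` is the next member to be run. Its change from compound 1 is hydrogen in place of methyl on an oxygen on an aromatic ring, which touches a different part of the shared core than the changes examined so far, all of which exchanged the group on the oxygen on the saturated carbon. For the measured compounds named here, no measured step therefore bears on this change, and the numbers do not show whether the series can move off the limit at all. The step from compound 1 to compound 4 in this assay is expected to be a step that the limit leaves unreadable from compound 1 to compound 4, a placeholder at the limit rather than a direction. Compound 4 is expected to give 8000 nM, within 3000 nM to 30000 nM, and most likely to be reported once more as a limit.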

Compound 4, inhibition constant: > 5000 nM
Compound 4: no number, only a limit; the forecaster's own chance of this, stated with the estimate: 75%; the middle value is on the limit's open side.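

In this assay compound 4 gives > 5000 nM, a limit and not a number. The step between compound 1 and compound 4, methoxy to hydroxy, therefore cannot be read. The compounds shown leave open whether any change to the shared core yields a measurable inhibition constant, since all remain at one value: the limit of > 5000 nM in this assay, at which 4 of the 4 values shown sit.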